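Chain-length series: removing the heptyl chain

The compounds below may be only part of what the source reports. "The series", "measured", "known", "first", "only" and "open" are said of these compounds alone.

Measured so far:
- compound 1 `CCCCc1cc2cn(COCCO)c(=O)nc2o1` gives a limit, > 400000 nM
- compound 2 `CCCCCCCCCCCc1cc2cn(COCCO)c(=O)nc2o1` gives 80000 nM
- compound 3 `CCCCCCCc1cc2cn(COCCO)c(=O)nc2o1` gives 400000 nM

In a functional assay on HEL cells (Homo sapiens), read by microscopy (on this read-out lower numbers stand for higher toxicity in this test and higher numbers for lower toxicity in this test), compound 3 stands highest of the two numbers; the nearest is compound 2, a 5.0-fold higher number from compound 2 to compound 3 (0.70 log units; beyond the scatter). For compound 1 only a limit is known, (the limit of > 400000 nM in this assay, at which 1 of the 3 values shown sits). Compound 4 `O=c1nc2occc2cn1COCCO` takes the change (hydrogen in place of heptyl on an aromatic carbon). Among the compounds with values here, the steps that bear on it run along the chain: an at least 5.0-fold lower number from compound 1 to compound 2 (0.69 log units; beyond the scatter) and a 5.0-fold higher number from compound 2 to compound 3 (0.70 log units; beyond the scatter), both beyond the scatter, with the shorter chain giving the higher number; a number no higher from compound 1 to compound 3 (the limit leaves the size open) leaves its size open. Going on to no chain, compound 4 is therefore expected to give a number no lower than compound 3 and quite possibly only a limit, a 1.3-fold higher number from compound 3 to compound 4 (0.10 log units; within the scatter). Compound 4 is estimated at 500000 nM, within 250000 nM to 1000000 nM.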

Compound 4, minimum cytotoxic concentration: > 400000 nM
Compound 4: a limit, no number; the forecaster's own chance of this, stated with the estimate: 70%; the middle value lies beyond the limit too.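

In this assay, hydrogen in place of heptyl on an aromatic carbon, next to the ring oxygen, gives a number no lower from compound 3 to compound 4 (the limit leaves the size open). Removing the chain entirely therefore brings no lower number, but it adds no measurable size to the trend seen for compound 2 and compound 3. The step between compound 1 and compound 4 cannot be read, and both compounds sit at a limit: the limit of > 400000 nM in this assay, at which 2 of the 4 values shown sit.

On these data alone, how far compound 4 lies beyond its limit stays open. Also open, as far as these compounds go, is whether an amine or a carboxylic acid on this carbon would give a readable number.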